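A few compounds are considered here, and "the series" means these few. Any claim that something is new, unique, unknown or untested is made for them only; others in the source may bear on it.

Series notes, quinazolinone-free working view of three measured compounds and one open position.

The read-out throughout is a functional assay on aorta with Alpha-1D adrenergic receptor (Rattus norvegicus) as the target; on this read-out higher numbers stand for an effect only at larger amounts of compound and lower numbers for an effect already at smaller amounts. Among the compounds with values here, compound 2 `CCCCn1nc(Cc2ccc(OC)c(OC)c2)c2ccccc2c1=O` is the only member of the set that returns a number: in this assay compound 2 gives 5400 nM. Compound 3 `CCCCn1nc(Cc2ccc(Cl)cc2)c2ccccc2c1=O` gives only a limit in this assay, > 100000 nM. Compound 1 `O=c1c2ccccc2c(Cc2ccc(Cl)cc2)nn1-c1ccc(Br)cc1` likewise gives only a limit in this assay, > 30000 nM.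

Compound 1 and compound 3 share one core and differ in one place: 4-bromophenyl in place of butyl on an aromatic nitrogen. The step from that change, a step that the two limits leave unreadable from compound 3 to compound 1, cannot be sized, since the two values sit at different limits, the limit of > 100000 nM in this assay, at which 1 of the 3 values shown sits, and (the limit of > 30000 nM in this assay, at which 1 of the 3 values shown sits). How the core of compound 2 differs from the core of compound 3 is not broken down here.

Compound 4 `COc1ccc(Cc2nn(-c3ccc(Br)cc3)c(=O)c3ccccc23)cc1OC` is not yet measured. It stands to compound 2 as compound 1 stands to compound 3: 4-bromophenyl in place of butyl on an aromatic nitrogen. The surroundings are not identical word for word, the position being meta to a large group in one pair and meta to a group of 8 heavy atoms in the other, so this is the same kind of change rather than the same change. Within the data shown here, the one earlier instance gives no readable size, so the expectation for compound 4 rests on compound 2 alone, with 5400 nM as the anchor and a wide spread around it. The expected step from compound 2 to compound 4 in this assay is a 1.5-fold higher number from compound 2 to compound 4 (0.17 log units; within the scatter). For compound 4 the estimate in this assay is 8000 nM, expected to fall between 2000 nM and 40000 nM, with a real chance that only a limit is returned.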

Compound 4, half-maximal effective concentration: > 100000 nM
Compound 4 gave a limit, no number (the forecaster's own chance of this, stated with the estimate: 35%); middle value at least 12-fold (1.09 log units) away from the limit.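

In this assay, 4-bromophenyl in place of butyl on an aromatic nitrogen gives an at least 18-fold higher number from compound 2 to compound 4 (1.26 log units; beyond the scatter), the only readable size for this change in the series, and that size is bounded on one side only. Compound 4 returns a limit rather than a number, the same limit as compound 3: the limit of > 100000 nM in this assay, at which 2 of the 4 values shown sit. The step between compound 3 and compound 1 cannot be read, so the two pairs agree only in that each 4-bromophenyl compound ends in a limit, and the size seen on the core of compound 2 is not shown to carry over to any other core.

Still open, as far as these compounds go, is how far the true value of compound 4 lies past its limit, and whether the shift follows from the loss of butyl, the entry of the aromatic ring or the entry of the bromine. A plain phenyl, a longer chain or an amine-bearing chain on that same aromatic nitrogen of the core of compound 2 would help to separate these parts of the change.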